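A side-chain exchange on compound 3

This account rests on a few compounds, and the source may have more. Where it says the series, first, only, none or still open, it means among the compounds named here.

Compound 1 `COc1ncc(-c2ccc3nc(NC(=O)N4CCCC4)nn3c2)cc1NS(=O)(=O)c1ccc(F)cc1`: 3570 nM
Compound 2 `COc1ncc(-c2ccc3nc(NC(=O)NC4CC4)nn3c2)cc1NS(=O)(=O)c1ccc(F)cc1`: 210 nM
Compound 3 `COc1ncc(-c2ccc3nc(NC(=O)NCCN(C)C)nn3c2)cc1NS(=O)(=O)c1ccc(F)cc1`: 800 nM

In a functional assay on A549 cells (Homo sapiens) for cytotoxicity, read by MTT assay, with a stated time of 72 h (a higher number here means a weaker inhibitor, a lower number a stronger inhibitor), compound 3 holds the middle place of the three, at 800 nM. It lies apart from its two neighbours, as shown by a 3.8-fold higher number from compound 2 to compound 3 (0.58 log units; beyond the scatter) and by a 4.5-fold lower number from compound 1 to compound 3 (0.65 log units; beyond the scatter).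

Compound 4 `COc1ncc(-c2ccc3nc(NC(=O)NCC(=O)N4CCOCC4)nn3c2)cc1NS(=O)(=O)c1ccc(F)cc1` has not yet been measured. It differs from compound 3 as follows: (morpholin-4-yl)carbonyl in place of (dimethylamino)methyl on a saturated chain carbon bound to an amide-type nitrogen. In short, (morpholin-4-yl)carbonyl replaces (dimethylamino)methyl on a saturated chain carbon bound to an amide-type nitrogen.

The closest measured guide is a 3.8-fold higher number from compound 2 to compound 3 (0.58 log units; beyond the scatter), a modest step that also alters the group on this amide-type nitrogen. The wider a 17-fold lower number from compound 1 to compound 2 (1.23 log units; beyond the scatter) shows that changes in this part can be large. Neither step gives a direction for the entering group, so no step beyond the scatter is expected, with a slight upward lean. The estimated change is a 1.3-fold higher number from compound 3 to compound 4 (0.10 log units; within the scatter). For compound 4 the expected value is 1000 nM, with an estimated range of 300 nM to 3500 nM.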

Compound 4, half-maximal inhibitory concentration: 2570 nM
Compound 4: middle estimate off by 2.6-fold (0.41 log units), on the low side; the measured number falls inside the stated range.
By their numbers in this assay, from the lowest: compound 2; then compound 3; then compounds 4 and 1 (each within the scatter of the next).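

In this assay the exchange of (dimethylamino)methyl for (morpholin-4-yl)carbonyl on the saturated chain carbon gives a 3.2-fold higher number from compound 3 to compound 4 (0.51 log units; beyond the scatter) and shows that the group carried on this chain still counts once the chain itself is kept. Against the cyclopropyl group, ((morpholin-4-yl)carbonyl)methyl gives a 12-fold higher number from compound 2 to compound 4 (1.09 log units; beyond the scatter) and so widens the spread seen on this amide-type nitrogen. Cyclopropylamino and (2-(dimethylamino)ethyl)amino had both stood clear of pyrrolidin-1-yl, but (((morpholin-4-yl)carbonyl)methyl)amino goes against that pattern, with a 1.4-fold lower number from compound 1 to compound 4 (0.14 log units; within the scatter) within the scatter.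

The compounds do not separate the carbonyl from the morpholine ring, which (morpholin-4-yl)methyl or (dimethylamino)carbonyl on the same carbon could do. No measurement shown here accounts for these steps.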